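A few compounds are considered here, and "the series" means these few. Any claim that something is new, unique, unknown or untested is made for them only; others in the source may bear on it.

Measured so far in a functional assay on DU-145 cells (Homo sapiens) for antiproliferative activity, read by propidium iodide staining, with a stated time of 96 h; on this read-out higher numbers stand for weaker inhibition and lower numbers for stronger inhibition:
compound 1 `CC(O)(CSc1cccc(S(F)(F)(F)(F)F)c1)C(=O)Nc1cccc(S(F)(F)(F)(F)F)c1`, 30300 nM
compound 2 `CC(O)(CSc1cccc(C(F)(F)F)c1)C(=O)Nc1cccc(S(F)(F)(F)(F)F)c1`, 19100 nM
compound 3 `CC(O)(COc1ccc(S(F)(F)(F)(F)F)cc1)C(=O)Nc1ccc(S(F)(F)(F)(F)F)cc1`, 24900 nM

Compound 1 and compound 2 share a core and differ by a group of 4 heavy atoms (1 carbon, 3 fluorine; no ring) in place of a group of 6 heavy atoms (5 fluorine, 1 sulfur; no ring), on an aromatic carbon. The step in this assay is a 1.6-fold lower number from compound 1 to compound 2 (0.20 log units; within the scatter). Compound 3 is built on a different core; the difference between the two cores is not broken down here. Compound 1 and compound 3 give values within the scatter of each other, so nothing can be said about their order.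

Compound 4 `CC(O)(COc1ccc(S(F)(F)(F)(F)F)cc1)C(=O)Nc1ccc(C(F)(F)F)cc1` is not yet measured and differs from compound 3 by a group of 4 heavy atoms (1 carbon, 3 fluorine; no ring) in place of a group of 6 heavy atoms (5 fluorine, 1 sulfur; no ring), on an aromatic carbon. This is the same kind of change as that from compound 1 to compound 2, not the same: in compound 2 the entering group sits meta to a large group, in compound 4 para to a large group. The expectation rests on that single earlier step. For compound 4 a step of a 1.6-fold lower number from compound 3 to compound 4 (0.19 log units; within the scatter) in this assay is expected, because the earlier step gave a 1.6-fold lower number from compound 1 to compound 2 (0.20 log units; within the scatter). Compound 4 is therefore estimated at 16000 nM, with a range from 8000 nM to 35000 nM.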

Compound 4, half-maximal inhibitory concentration: 27400 nM
The estimate for compound 4 lay 1.7-fold (0.23 log units) below the measured number; measured number inside the range.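

In this assay, trifluoromethyl in place of the group of 6 heavy atoms, on an aromatic carbon para to a large group, gives a 1.1-fold higher number from compound 3 to compound 4 (0.04 log units; within the scatter) and so no readable change. Set beside the earlier step, the same change does not separate the two cores: the same change on two cores in this assay, a 1.6-fold lower number (0.20 log units; within the scatter) from compound 1 to compound 2 and a 1.1-fold higher number (0.04 log units; within the scatter) from compound 3 to compound 4, 1.7-fold (0.24 log units) apart, within the scatter of two such steps. Going by these compounds alone, this shows that nothing in these two pairs points to a core-dependent outcome for the change, but it does not show that the change is neutral or that it transfers reliably, since both steps and the gap between them lie within the scatter and only two cores are covered.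

As far as these compounds go, whether an amine, a carboxylic acid or a nitrile on that aromatic carbon would give a step beyond the scatter remains open. Also open, from the compounds shown here alone, is how this change behaves on further cores, where a step of readable size could test whether it carries from one core to another.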